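The source may hold more compounds than are shown below. What is called first, only, known or untested is meant among the compounds shown, and "the series" means these compounds.

Measured compounds:
compound 1, `COc1cc(Nc2ncc(C(F)(F)F)c(N3Cc4cccc(N(C)S(C)(=O)=O)c4C3)n2)cc(OC)c1`, gives 630 nM;
compound 2, `COc1cc(N2CCN(C(C)=O)CC2)ccc1Nc1ncc(C(F)(F)F)c(N2Cc3cccc(N(C)S(C)(=O)=O)c3C2)n1`, gives 1600 nM;
compound 3, `CN(c1cccc2c1CN(c1nc(Nc3ccc(Nc4ccccc4)cc3)ncc1C(F)(F)F)C2)S(C)(=O)=O`, reports only a limit, given below.

These three compounds share a core and were tested in a functional assay on OVCAR-3 cells (Homo sapiens) for antiproliferative activity, read by spectrophotometry, with a stated time of 2 days; on this read-out higher numbers stand for weaker inhibition of growth and lower numbers for stronger inhibition of growth. Compound 1 has the lowest of the two numbers recorded; the nearest is compound 2, whose number is higher by a margin beyond the usual scatter. Compound 3 does not yield a number in this assay but only a limit, > 50000 nM, which is the limit of > 50000 nM in this assay, at which 1 of the 3 values shown sits.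

The step followed here leads from compound 1 to compound 4, `COc1cc(Nc2ncc(C(F)(F)F)c(N3Cc4cccc(N(C)S(C)(=O)=O)c4C3)n2)cc(C(F)(F)F)c1`, which has not yet been measured in this assay. The change is trifluoromethyl in place of methoxy on an aromatic carbon. Going by the values given here, no step between measured compounds is available for this change, so no measured size can be quoted for it. The expectation is a modest weakening of growth inhibition, a 2.4-fold higher number from compound 1 to compound 4 (0.38 log units; beyond the scatter), a step that may or may not reach beyond the scatter. Compound 4 is therefore estimated at 1500 nM in this assay, with a range from 500 nM to 5000 nM.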

Compound 4, concentration for 50% growth inhibition: > 30000 nM
Compound 4 gave a limit, no number; the forecaster's own chance of this, stated with the estimate: 5%; at least 20-fold (1.30 log units) between middle value and limit.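

In this assay, trifluoromethyl in place of methoxy on this aromatic carbon, meta to a methoxy group, gives a large step: an at least 47-fold higher number from compound 1 to compound 4 (1.67 log units; beyond the scatter). Compound 4 gives a limit and not a number: the limit of > 30000 nM in this assay, at which 1 of the 4 values shown sits. Going by these compounds alone, a single exchange on the 3,5-dimethoxyphenyl group is thus enough for a large loss of growth inhibition, something the earlier compounds, which differ from compound 1 in another place, could not show.

The compounds shown leave open whether this loss comes with the departure of the methoxy group or with the arrival of trifluoromethyl. As far as these compounds go, it also remains open how a hydroxyl group, an amine, a methyl group or a chlorine atom on this same aromatic carbon would compare with compound 1.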